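Ether linkage in place of the anilino link on the core

The source may hold more compounds than are shown below. What is called first, only, known or untested is meant among the compounds shown, and "the series" means these compounds.

Compound 2 `Cc1ccc(Nc2ncc3c(n2)N(C)C(=O)N(c2cc(NC(=O)c4cccc(C(F)(F)F)c4)ccc2C)C3)cc1N(C)C` gives 28 nM in a functional assay on K562 cells (Homo sapiens) for antiproliferative activity, read by CellTiter-Glo and CCK-8 assay, with a stated time of 72 h (a higher number here means a weaker inhibitor of growth, a lower number a stronger inhibitor of growth), the highest of the three numbers shown, though within the scatter of compound 3 `Cc1ccc(Nc2ncc3c(n2)N(C)C(=O)N(c2cc(NC(=O)c4cccc(-c5ccccc5)c4)ccc2C)C3)cc1N` at 23 nM and of compound 1 `Cc1ccc(Nc2ncc3c(n2)N(C)C(=O)N(c2cc(NC(=O)c4cccc(C(F)(F)F)c4)ccc2C)C3)cc1C` at 17 nM. For the measured compounds named here, the only single-point step measured, a 1.6-fold higher number from compound 1 to compound 2 (0.22 log units; within the scatter), concerns the amine substituent and not the linkage. Compound 4 `Cc1ccc(Oc2ncc3c(n2)N(C)C(=O)N(c2cc(NC(=O)c4cccc(C(F)(F)F)c4)ccc2C)C3)cc1N` differs from compound 2 by 3-amino-4-methylphenoxy in place of (3-(dimethylamino)-4-methylphenyl)amino on an aromatic carbon. Going by the values given here, no measured pair exchanges the anilino link for an ether, so this part of the change rests on no step; the amino substituent alone is carried by compound 3 without a shift beyond the scatter. Compound 4 is therefore estimated at 120 nM (range 25 nM to 600 nM), an expected step of a 4.3-fold higher number from compound 2 to compound 4 (0.63 log units; beyond the scatter) with wide uncertainty.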

Compound 4, concentration for 50% growth inhibition: 13 nM
Estimate against measurement, compound 4: 9.2-fold (0.97 log units) above; the measured number lies below the stated range.
By their numbers in this assay, from the lowest: compounds 4, 1, 3 and 2 (each within the scatter of the next, the first and the last beyond it).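

In this assay, 3-amino-4-methylphenoxy on the aromatic carbon between two ring nitrogen atoms is accepted, with a 2.2-fold lower number from compound 2 to compound 4 (0.33 log units; beyond the scatter) against (3-(dimethylamino)-4-methylphenyl)amino. Against (3,4-dimethylphenyl)amino, the same exchange gives a 1.3-fold lower number from compound 1 to compound 4 (0.12 log units; within the scatter) and no loss of growth inhibition, so the anilino link is not needed in these compounds. No measurement on hand accounts for either step.

Both steps change the link and the ring substituents together, so the ether's own share stays unresolved. Open too, from the compounds shown here alone, is whether a thioether or methylene link matches the ether.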